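Chloro addition on the anilide ring: notes on a small series

The compounds below may be only part of what the source reports. "The series", "measured", "known", "first", "only" and "open" are said of these compounds alone.

Measured compounds:
compound 1 `O=C(Nc1ccc(Cl)cc1Cl)c1ccc2cccnc2c1O` — 610 nM
compound 2 `O=C(Nc1cccc(C(F)(F)F)c1)c1cc(F)ccc1O` — 970 nM
compound 3 `O=C(Nc1ccc(Cl)cc1)c1ccc2cccnc2c1O` — 630 nM

Compounds 1 and 3 share one core; compound 2 carries another, and the difference between the two cores is not broken down here. In a functional assay on HL-60 cells (Homo sapiens) for cytotoxicity, read by luminescence and CellTiter-Glo, with a stated time of 3 days (on this read-out higher numbers stand for weaker inhibition and lower numbers for stronger inhibition), compound 1 gives 610 nM, compound 3 gives 630 nM and compound 2 gives 970 nM; all three values lie within the scatter of one another, so no order among them can be read.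

Within the data shown here, the one single-point change measured so far is chloro in place of hydrogen on an aromatic carbon, which gave a 1.0-fold lower number from compound 3 to compound 1 (0.01 log units; within the scatter).

Compound 4 `O=C(Nc1ccc(Cl)c(C(F)(F)F)c1)c1cc(F)ccc1O` is not yet measured. It arises from compound 2 by chloro in place of hydrogen on an aromatic carbon. This is the same kind of change as that from compound 3 to compound 1, not the same: in compound 1 the chloro enters ortho to a large group and meta to a chloro group, in compound 4 ortho to a trifluoromethyl group and para to a large group.

The expected step is a 1.0-fold lower number from compound 2 to compound 4 (0.01 log units; within the scatter), an expectation that rests on the earlier step of a 1.0-fold lower number from compound 3 to compound 1 (0.01 log units; within the scatter), which was flat. Compound 4 is therefore estimated at 950 nM in this assay, expected to fall between 400 nM and 2300 nM.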

Compound 4, half-maximal inhibitory concentration: 600 nM
The estimate for compound 4 lay 1.6-fold (0.20 log units) above the measured number; low and high end bracket the measured number.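

In this assay, chloro in place of hydrogen on an aromatic carbon gave a 1.6-fold lower number from compound 2 to compound 4 (0.21 log units; within the scatter), so on the core of compound 2, as on the core of compound 3, this step cannot be told from no change. Set side by side, the two steps cannot be told apart either: the same change on two cores in this assay, a 1.0-fold lower number (0.01 log units; within the scatter) from compound 3 to compound 1 and a 1.6-fold lower number (0.21 log units; within the scatter) from compound 2 to compound 4, 1.6-fold (0.19 log units) apart, within the scatter of two such steps. This shows that the change can be carried from one core to the other in this series with no step beyond the scatter, although the chloro enters different surroundings in the two pairs; it does not show that chloro has no effect at all, and two pairs give no rule for other cores or other places on the ring.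

The compounds shown leave open whether a nitrile, an amine or a carboxylic acid in place of the chloro would give a step beyond the scatter. Also open is what the difference between the two cores contributes on its own; no pair shown isolates it.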